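This account rests on a few compounds, and the source may have more. Where it says the series, first, only, none or still open, it means among the compounds named here.

Compound 1 `C=C1C[C@]23C[C@@]1(O)CC[C@H]2c1ccc(O)c(C)c1[C@@H]3Cn1cc(-c2ccccn2)nn1`: > 20000 nM, a limit of the assay.
Compound 2 `C=C1C[C@]23C[C@@]1(O)CC[C@H]2c1cc(Br)c(O)c(C)c1[C@@H]3Cn1cc(-c2ccccn2)nn1`: > 20000 nM, a limit of the assay.

In a functional assay on A549 cells (Homo sapiens) for cytotoxicity, read by MTT assay, with a stated time of 4 days (on this read-out lower numbers stand for stronger inhibition and higher numbers for weaker inhibition), compound 2 gives only a limit, > 20000 nM. Compound 1 likewise gives only the limit > 20000 nM. Between them lies a step that the two limits leave unreadable from compound 1 to compound 2, as the limit of > 20000 nM in this assay, at which 2 of the 2 values shown sit, makes clear. Compound 3 `C=C1C[C@]23C[C@@]1(O)CC[C@H]2c1cc(Br)c(O)c(C)c1[C@@H]3Cn1cc(-c2ccc(C)cc2)nn1` differs from compound 2 by 4-methylphenyl in place of pyridin-2-yl on an aromatic carbon. Among the compounds with values here, no measured step bears on this change, and both measured compounds sit at the limit. Compound 3 is therefore expected to remain weak, estimated at 30000 nM with a range from 8000 nM to 100000 nM. The step that the limit leaves unreadable from compound 2 to compound 3 is expected to lie within the scatter.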

Compound 3, half-maximal inhibitory concentration: > 20000 nM
Compound 3 ended at the assay's limit; the forecaster's own chance of this, stated with the estimate: 75%; the middle value lies beyond the limit too.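

Compound 2 and compound 3 both give only a limit, so no step between them can be read: the limit of > 20000 nM in this assay, at which 3 of the 3 values shown sit.

The compounds shown leave open whether exchanging pyridin-2-yl for 4-methylphenyl changes cytotoxicity at all.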